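Isopropyl to tert-butyl urea on the anilino core

The source may report more compounds than this note shows. Statements on the series, on what has been measured and on what is new or still open speak of the compounds shown alone.

Compound 1 `Cc1cccc(Oc2ccc(C#N)cc2S(=O)(=O)NC(=O)NC(C)C)c1` gives 1690 nM in a functional assay on HEK293 cells for antagonist activity at thromboxane A2 receptor (Homo sapiens), read by fluorescence and calcium flux; on this read-out higher numbers stand for weaker inhibition and lower numbers for stronger inhibition. Compound 2 `Cc1cccc(Oc2ccc(C#N)cc2S(=O)(=O)NC(=O)NC(C)(C)C)c1` carries methyl in place of hydrogen on a saturated chain carbon bound to an amide-type nitrogen and two saturated chain carbons and gives 690 nM, a step of a 2.4-fold lower number from compound 1 to compound 2 (0.39 log units; beyond the scatter). Compound 3 `Cc1ccccc1Nc1ccc(C#N)cc1S(=O)(=O)NC(=O)NC(C)C` differs from compound 1 by (2-methylphenyl)amino in place of 3-methylphenoxy on an aromatic carbon; in this assay compound 3 gives 10100 nM, a step of a 6.0-fold higher number from compound 1 to compound 3 (0.78 log units; beyond the scatter), and it stands as the highest number of the three.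

Compound 4 `Cc1ccccc1Nc1ccc(C#N)cc1S(=O)(=O)NC(=O)NC(C)(C)C` is not yet measured. It differs from compound 3 by methyl in place of hydrogen on a saturated chain carbon bound to an amide-type nitrogen and two saturated chain carbons, the same change as that from compound 1 to compound 2, at the same place. The expectation for compound 4 therefore rests on the step of a 2.4-fold lower number from compound 1 to compound 2 (0.39 log units; beyond the scatter) applied to compound 3 at 10100 nM, giving an expected 2.4-fold lower number from compound 3 to compound 4 (0.38 log units; beyond the scatter). Compound 4 is estimated at 4200 nM, with a range of 2000 nM to 9000 nM expected.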

Compound 4, half-maximal inhibitory concentration: 4780 nM
Compound 4: the middle estimate sits 1.1-fold (0.06 log units) below what was measured; measured number inside the range.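

In this assay, isopropyl to tert-butyl also lowers the number on the core of compound 3, with a 2.1-fold lower number from compound 3 to compound 4 (0.32 log units; beyond the scatter), and the step carries over from the core of compound 1 without a discernible change in size: the same change on two cores in this assay, a 2.4-fold lower number (0.39 log units; beyond the scatter) from compound 1 to compound 2 and a 2.1-fold lower number (0.32 log units; beyond the scatter) from compound 3 to compound 4, 1.2-fold (0.06 log units) apart, within the scatter of two such steps. The replacement of 3-methylphenoxy by (2-methylphenyl)amino likewise holds on the tert-butyl compounds, with a 6.9-fold higher number from compound 2 to compound 4 (0.84 log units; beyond the scatter), and matches its earlier size: the same change on two cores in this assay, a 6.0-fold higher number (0.78 log units; beyond the scatter) from compound 1 to compound 3 and a 6.9-fold higher number (0.84 log units; beyond the scatter) from compound 2 to compound 4, 1.2-fold (0.06 log units) apart, within the scatter of two such steps. Across these four compounds the two changes behave as independent steps, but this does not show that either would carry over to other cores or to other assays.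

The aromatic change alters the linking atom and the methyl place together, and (3-methylphenyl)amino or 2-methylphenoxy would be needed to separate the two. From the compounds shown here alone, whether cyclopentyl or a longer chain in place of tert-butyl would extend the step remains open.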